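Swapping a ring group on two histone deacetylase 8 inhibitors

The compounds below may be only part of what the source reports. "The series", "measured", "known", "first", "only" and "open" are said of these compounds alone.

Compound 1 `COc1ccc(C(=O)c2ccc3c(ccn3Cc3ccc(C(=O)NO)cc3)c2)cc1OC` and compound 2 `O=C(NO)c1ccc(Cn2ccc3cc(C(=O)c4ccc(F)cc4)ccc32)cc1` share one core, and in an assay on isolated protein for inhibition of histone deacetylase 8 (Homo sapiens) (on this read-out lower numbers stand for stronger inhibition and higher numbers for weaker inhibition), compound 1 gives 756 nM while compound 2 gives 1240 nM. The only difference between them is 4-fluorophenyl in place of 3,4-dimethoxyphenyl on a carbonyl carbon and it made a 1.6-fold higher number from compound 1 to compound 2 (0.21 log units; within the scatter). Compound 3 `COc1ccc(C(=O)c2ccc3c(ccn3S(=O)(=O)c3cccc(/C=C/C(=O)NO)c3)c2)cc1OC` gives 1420 nM in this assay; how its core differs from that of compound 1 is not broken down here. Compound 4 `O=C(/C=C/c1cccc(S(=O)(=O)n2ccc3cc(C(=O)c4ccc(F)cc4)ccc32)c1)NO` has not yet been measured. It differs from compound 3 by 4-fluorophenyl in place of 3,4-dimethoxyphenyl on a carbonyl carbon, the same change at the same place as between compound 1 and compound 2. A similar outcome is expected, because the earlier step of a 1.6-fold higher number from compound 1 to compound 2 (0.21 log units; within the scatter) stayed small, so for compound 4 the expected step is a 1.6-fold higher number from compound 3 to compound 4 (0.21 log units; within the scatter). Compound 4 is estimated at 2300 nM, with a range from 1200 nM to 4500 nM.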

Compound 4, half-maximal inhibitory concentration: 2750 nM
The estimate for compound 4 lay 1.2-fold (0.08 log units) below the measured number; low and high end bracket the measured number.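

In this assay, putting 4-fluorophenyl in place of 3,4-dimethoxyphenyl on a carbonyl carbon gave a 1.9-fold higher number from compound 3 to compound 4 (0.29 log units; within the scatter). Set beside the earlier case, the change behaves alike on both cores: the same change on two cores in this assay, a 1.6-fold higher number (0.21 log units; within the scatter) from compound 1 to compound 2 and a 1.9-fold higher number (0.29 log units; within the scatter) from compound 3 to compound 4, 1.2-fold (0.07 log units) apart, within the scatter of two such steps. This shows that the swap carried over between these two cores in this one assay; with both steps within the scatter, it does not show that the swap itself alters inhibition, or that a further core would follow the same pattern.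

Among the compounds shown here, only two groups appear in this place, so how an amine or a carboxylic acid on the phenyl ring would fare stays open. Also open, on these data alone, is whether the two cores would still track each other with such groups.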